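Urea series: carbamoylamino insertion with a 3-chlorophenyl end

A few compounds are considered here, and "the series" means these few. Any claim that something is new, unique, unknown or untested is made for them only; others in the source may bear on it.

Measured so far:
Compound 1, `COc1cc(NC(C)CCCNC(=O)Nc2cccc(F)c2)c2ncccc2c1`, gives 21000 nM in a functional assay on CCRF-CEM cells (Homo sapiens) for inhibition, read by MTT assay, with a stated time of 72 h; a lower number here means a stronger inhibitor, a higher number a weaker inhibitor.
Compound 2, `COc1cc(NC(C)CCCNC(=O)Nc2cccc(Cl)c2)c2ncccc2c1`, gives 22000 nM in this assay.
Compound 3, `COc1cc(NC(C)CCCNC(=O)NNC(=O)Nc2ccc(C(F)(F)F)cc2)c2ncccc2c1`, gives 18000 nM in this assay.

Compound 1 sits second highest of the three numbers; its nearest neighbour is compound 2 and its furthest is compound 3, and both gaps are within the scatter, so the three compounds cannot be ordered. Among the compounds with values here, the only single-point step among the measured compounds is a 1.0-fold higher number from compound 1 to compound 2 (0.02 log units; within the scatter), chloro in place of fluoro on an aromatic carbon. Within the data shown here, no step is computed between compound 1 and compound 3, but their two values show that the carbamoylamino link with a different aryl end leaves the number within the scatter.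

Compound 4, `COc1cc(NC(C)CCCNC(=O)NNC(=O)Nc2cccc(Cl)c2)c2ncccc2c1`, has not been measured in this assay. It differs from compound 1 as follows: ((3-chlorophenyl)carbamoyl)amino in place of 3-fluorophenyl on an amide-type nitrogen.

Both kinds of change present in compound 4 are thus covered: the halogen swap, which gave a 1.0-fold higher number from compound 1 to compound 2 (0.02 log units; within the scatter), and the carbamoylamino insertion, which compounds 1 and 3 show to be within the scatter. The step of a 1.1-fold lower number from compound 1 to compound 4 (0.02 log units; within the scatter) is therefore expected to stay within the scatter. Compound 4 is estimated at 20000 nM, with a range from 9000 nM to 45000 nM.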

Compound 4, half-maximal inhibitory concentration: 81000 nM
Compound 4: middle estimate off by 4.1-fold (0.61 log units), on the low side; measured number above the stated range.
By their numbers in this assay, from the lowest: compounds 3, 1 and 2 (each within the scatter of the next); then compound 4.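

In this assay, the carbamoylamino insertion on the amide-type nitrogen is not silent when the aryl end is halogenated in this way: ((3-chlorophenyl)carbamoyl)amino in place of 3-chlorophenyl gives a 3.7-fold higher number from compound 2 to compound 4 (0.57 log units; beyond the scatter) and, in place of 3-fluorophenyl, gives a 3.9-fold higher number from compound 1 to compound 4 (0.59 log units; beyond the scatter) as well. The aryl end also counts once this longer link is present, which the halogen swap on the shorter urea did not show: on the same link, 3-chlorophenyl in place of 4-(trifluoromethyl)phenyl gives a 4.5-fold higher number from compound 3 to compound 4 (0.65 log units; beyond the scatter) as the widest of the new steps. The insertion therefore has no single effect across the shown compounds, since compound 4 stands apart from compound 1 and compound 2 while compound 3, with the same link and a 4-(trifluoromethyl)phenyl end, stays within the scatter of both.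

Open, on these data alone, is how an unsubstituted phenyl end, a methoxy group on the ring or a longer alkyl chain in place of the link would read on the same scale, so the roles of the aryl end and the link cannot yet be separated beyond these four compounds. Nothing measured here accounts for the gap between compound 3 and compound 4.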